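Nitro in Place of Cyano: An Expected Cytotoxicity Step

A few compounds are considered here, and "the series" means these few. Any claim that something is new, unique, unknown or untested is made for them only; others in the source may bear on it.

Three compounds share one core. Compound 1 `Cn1cnnc1SCC(=O)N/N=c1/scc(-c2ccc([N+](=O)[O-])cc2)n1-c1ccccc1` has no reported result: in a functional assay on C6 cells (Rattus norvegicus) for cytotoxicity, read by MTT assay, with a stated time of 24 h (on this read-out lower numbers stand for stronger inhibition and higher numbers for weaker inhibition), compound 1 shows "not determined" (no result reported). Compound 2 `Cn1nnnc1SCC(=O)N/N=c1/scc(-c2ccc(C#N)cc2)n1-c1ccccc1` is the only compound with a number: in this assay compound 2 gives 23.3 ug/mL, so on the numbers shown it stands alone, with nothing measured to set beside it. Compound 3 `Cn1nnnc1SCC(=O)N/N=c1/scc(-c2ccc([N+](=O)[O-])cc2)n1-c1ccccc1` differs from compound 2 in one place, (nitro in place of cyano on an aromatic carbon), that is, nitro in place of cyano on an aromatic carbon. Among the measured compounds shown here, no measured pair shows what such a swap does here, so the size of the step is unknown; the expectation is a change that stays within the usual scatter, in no particular direction. The step of a 1.1-fold lower number from compound 2 to compound 3 (0.05 log units; within the scatter) is estimated to be small. Compound 3 is expected to give about 21 ug/mL in this assay, with an estimated range from 8 ug/mL to 55 ug/mL.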

Compound 3, half-maximal inhibitory concentration: > 200 ug/mL
Compound 3: no number, only a limit (the forecaster's own chance of this, stated with the estimate: 10%); at least 9.5-fold (0.97 log units) between middle value and limit.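

In this assay, going from 4-cyanophenyl to 4-nitrophenyl gives an at least 8.5-fold higher number from compound 2 to compound 3 (0.93 log units; beyond the scatter), which shows that this place on the aromatic ring, para to a large group, is sensitive to the group it carries. Compound 3 gives > 200 ug/mL, which is a limit of the assay and not a number. The step is therefore a minimum rather than an exact size, and it shows that inhibition is weaker with nitro at this place than with cyano.

On these data alone, only cyano and nitro appear here, so how an amine, a carboxylic acid or a methoxy group would read at this place stays open. Among the compounds shown here, compound 1 also carries 4-nitrophenyl but has no reported result, so no step involving compound 1 can be read.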